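Methyl for methoxy on the aryl urea ring

A few compounds are considered here, and "the series" means these few. Any claim that something is new, unique, unknown or untested is made for them only; others in the source may bear on it.

Measured so far:
compound 1 `O=C(NCC1(c2ccccc2)CCCCC1)Nc1ccccc1`: 2300 nM
compound 2 `COc1ccc(NC(=O)NCC2(c3ccccc3)CCCCC2)cc1`: 4900 nM

Both were run in an assay on microsomes from intestine for inhibition of acyl-CoA:cholesterol acyltransferase (Oryctolagus cuniculus); a higher number here means a weaker inhibitor, a lower number a stronger inhibitor. For the measured compounds named here, compound 2 stands highest of the two numbers, with compound 1 at the lower one; the single measured step, a 2.1-fold higher number from compound 1 to compound 2 (0.33 log units; beyond the scatter), came from methoxy in place of hydrogen on an aromatic carbon. The next compound, compound 3 `Cc1ccc(NC(=O)NCC2(c3ccccc3)CCCCC2)cc1`, differs from compound 2 by methyl in place of methoxy on an aromatic carbon. Going by the values given here, no measured step exchanges methyl for methoxy, so the only guide is the modest shift already seen on adding methoxy, which suggests a methyl on the same carbon should fall near compound 2 or somewhat below it, between the two measured values. Compound 3 is therefore expected at about 3500 nM, range 1800 nM to 7000 nM, meaning an expected step of a 1.4-fold lower number from compound 2 to compound 3 (0.15 log units; within the scatter) that stays within or barely beyond the scatter.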

Compound 3, half-maximal inhibitory concentration: 4500 nM
Compound 3: the middle estimate sits 1.3-fold (0.11 log units) below what was measured; the range from low to high includes it.
By their numbers in this assay, from the lowest: compounds 1, 3 and 2 (each within the scatter of the next, the first and the last beyond it).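

In this assay, methyl in place of methoxy on this aromatic carbon, para to a large group, gives a 1.1-fold lower number from compound 2 to compound 3 (0.04 log units; within the scatter) and so does not separate the two groups, even though the hydrogen-bond acceptor of methoxy is gone. Set against hydrogen on the same carbon, methyl gives a 2.0-fold higher number from compound 1 to compound 3 (0.29 log units; within the scatter) and stays inside the scatter, so the step seen with methoxy does not stand as a clear difference between methoxy and methyl. No measurement on hand accounts for these numbers.

Still open, on these data alone, is whether any group on this carbon can move the number beyond the scatter in the direction of a stronger inhibitor. An amine, a carboxylic acid or a chlorine atom here would test how wide the tolerance of this position is.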